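Working notes: from compound 2 to compound 4

A few compounds are considered here, and "the series" means these few. Any claim that something is new, unique, unknown or untested is made for them only; others in the source may bear on it.

Measured so far in an ADME assay on HEL cells (Homo sapiens) for cytotoxicity, read by cell counting, with a stated time of 3 days; a lower number here means that less compound is tolerated, a higher number that more compound is tolerated
- compound 1 (`CCCCCc1ccc(-c2oc3nc(=O)n([C@H]4C[C@H](OC(C)=O)[C@@H](COC(C)=O)O4)cc3c2C#Cc2ccc(C)cc2)cc1`): "not determined" (no result reported)
- compound 2 (`CCCCCc1ccc(C#Cc2c(-c3ccc(C)cc3)oc3nc(=O)n([C@H]4C[C@H](OC(C)=O)[C@@H](COC(C)=O)O4)cc23)cc1`): "not determined" (no result reported)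
- compound 3 (`CCCCCc1ccc(-c2oc3nc(=O)n([C@H]4C[C@H](OC(C)=O)[C@@H](COC(C)=O)O4)cc3c2C#CCCO)cc1`): 2660 nM

Compound 2 has no single number on this read-out, and compound 1 is in the same position. For the measured compounds named here, that leaves compound 3 as the only compound with a value, so compound 2 cannot be ranked against anything.

Compound 4 (`CC(=O)OC[C@H]1O[C@@H](n2cc3c(C#Cc4ccc(C)cc4)c(-c4ccc(C)cc4)oc3nc2=O)C[C@@H]1OC(C)=O`) has not yet been measured. The structural change is hydrogen in place of butyl on a saturated chain carbon bound to an aromatic carbon and amounts to hydrogen in place of butyl on a saturated chain carbon bound to an aromatic carbon. Cut one bond further out, this reads pentyl to methyl, or 4-pentylphenyl to 4-methylphenyl.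

Going by the values given here, no pair of measured compounds shows the effect of this change, and the missing value for compound 2 leaves no starting point for a step. Among the compounds with values here, the only anchor is compound 3 at 2660 nM and the expectation from it is tentative: a modest step in this assay toward more compound tolerated, with wide uncertainty in its size. For compound 4 the estimated value is 8000 nM with an expected range from 2000 nM to 50000 nM and the measurement is still to come.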

Compound 4, half-maximal cytotoxic concentration: 8770 nM
Compound 4: middle estimate off by 1.1-fold (0.04 log units), on the low side; low and high end bracket the measured number.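

For the compounds shown here, compound 2 has no single number in this assay, and no step from it to compound 4 can be read from this result. The compounds shown leave open how the change from 4-pentylphenyl to 4-methylphenyl alone bears on the read-out in this assay. No supporting data on this result are available.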